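The source may hold more compounds than are shown below. What is called first, only, known or untested is meant among the compounds shown, and "the series" means these compounds.

Compound 1 `CN(C)C(=O)CCNC(=O)c1cc(-c2ccc(F)cc2)no1` is the reference here. In an ADME assay on microsomes from liver (Homo sapiens) for metabolic stability, with a stated time of 0.5 h, tested at 0.5 mg/mL (on this read-out lower numbers stand for a less stable compound and higher numbers for a more stable compound), compound 1 gives 87%, the lowest of the two plain numbers measured. Compound 3 `CN(C)C(=O)CCN(C)C(=O)c1cc(-c2ccc(F)cc2)no1`, with methyl in place of hydrogen on an amide-type nitrogen, gives 98% in this assay, a step of a number 11 percentage points higher from compound 1 to compound 3 (beyond the scatter). Compound 2 `CN(C)C(=O)CCNC(=O)c1cc(-c2ccccc2F)no1`, with 2-fluorophenyl in place of 4-fluorophenyl on an aromatic carbon, gives > 100% in this assay, which is a limit of the assay rather than a number (the limit of > 100% in this assay, at which 1 of the 3 values shown sits). That step is a number at least 13 percentage points higher from compound 1 to compound 2 (beyond the scatter). Compound 4 `CC(CC(=O)N(C)C)NC(=O)c1cc(-c2ccc(F)cc2)no1` has not yet been measured; it differs from compound 1 by methyl in place of hydrogen on a saturated chain carbon bound to an amide-type nitrogen and a saturated chain carbon. Neither measured step touches this chain carbon, so neither bears on it directly; the closest comparison is the added methyl of compound 3, whose step was modest. The expected step of a number 3 percentage points higher from compound 1 to compound 4 (within the scatter) is therefore small, likely within the scatter or a little upward. Compound 4 is estimated at 90% in this assay, with a range from 76% to 100%.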

Compound 4, percent of the compound remaining: 91%
Compound 4: middle estimate off by 1 percentage points, on the low side, within the range that was stated.
By their numbers in this assay, from the lowest: compounds 1, 4 and 3 (each within the scatter of the next, the first and the last beyond it). At a limit, above all of these: compound 2.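

On the saturated chain carbon bound to an amide-type nitrogen and a saturated chain carbon, the added methyl gives a number 4 percentage points higher from compound 1 to compound 4 (within the scatter) in this assay. This is the first reading at this position, and it differs from the methyl on the amide-type nitrogen, which gave a number 11 percentage points higher from compound 1 to compound 3 (beyond the scatter), so among these compounds the same small group does not read alike at both places. Nothing available here gives a reason for the step at the chain carbon.

Still open, from the compounds shown here alone, is whether a larger group on this chain carbon, such as an ethyl or a phenyl, or a different one, such as a hydroxyl or an amine, would also stay within the scatter of compound 1. Also open, going by these compounds, is how this methyl would read in one compound together with the methyl on the amide-type nitrogen.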